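This account rests on a few compounds, and the source may have more. Where it says the series, first, only, none or still open, it means among the compounds named here.

Compound 1 `Cc1ccc(-n2cc(CNC(=O)c3cccc4c3cnn4C(C)C)nn2)cc1C` was examined in a functional assay on MCF7 cells (Homo sapiens) for inhibition, read by MTT assay, with a stated time of 72 h; a lower number here means a stronger inhibitor, a higher number a weaker inhibitor. In this assay compound 1 gives > 40000 nM, which is a limit of the assay rather than a number. Two relatives share the same core and differ from compound 1 only in the group on an aromatic nitrogen of the five-membered ring. Compound 2 `CC(C)n1ncc2c(C(=O)NCc3cn(-c4cccc(Br)c4)nn3)cccc21` carries 3-bromophenyl there. In this assay compound 2 gives > 40000 nM, again a limit. Compound 3 `COc1ccc(-n2cc(CNC(=O)c3cccc4c3cnn4C(C)C)nn2)cc1` carries 4-methoxyphenyl. In this assay compound 3 gives > 40000 nM, also a limit. Accordingly the step that the two limits leave unreadable from compound 1 to compound 2, the step that the two limits leave unreadable from compound 1 to compound 3 and the step that the two limits leave unreadable from compound 2 to compound 3 cannot be read in size, since (the limit of > 40000 nM in this assay, at which 3 of the 3 values shown sit).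

Compound 4 `CC(C)n1ncc2c(C(=O)NCc3cn(Cc4ccccc4)nn3)cccc21` has not yet been measured. It differs from compound 1 in this way: benzyl in place of 3,4-dimethylphenyl on an aromatic nitrogen. As far as these compounds go, the measured steps on this nitrogen bear on it only in that none of them brought any compound to a readable value; their size stays unknown, so no direction can be drawn from them. The expectation is therefore that compound 4 also returns a limit in this assay, with an estimated step that the limit leaves unreadable from compound 1 to compound 4 amounting to nothing beyond the scatter. Compound 4 is estimated at 45000 nM, within a range of 20000 nM to 120000 nM.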

Compound 4, half-maximal inhibitory concentration: 9170 nM
For compound 4 the middle estimate is 4.9-fold (0.69 log units) above the measured one; the measured number lies below the stated range.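

In this assay, this nitrogen of the five-membered ring now gives a readable value, and the three replacements of a directly attached aromatic group by benzyl give an at least 4.3-fold lower number from compound 1 to compound 4 (0.63 log units; beyond the scatter), an at least 4.3-fold lower number from compound 3 to compound 4 (0.63 log units; beyond the scatter) and an at least 4.3-fold lower number from compound 2 to compound 4 (0.63 log units; beyond the scatter). The exchange of 3,4-dimethylphenyl for benzyl keeps one six-membered aromatic ring of carbon only and brings in no hydrogen-bond donor, no hydrogen-bond acceptor and no net charge, so none of these counts separates compound 4 from compound 1. The three steps to compound 4 give only a minimum size, and the steps among compound 1, compound 2 and compound 3 cannot be read, since each of those compounds gives a limit rather than a number: the limit of > 40000 nM in this assay, at which 3 of the 4 values shown sit.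

The compounds shown leave open whether a longer chain such as 2-phenylethyl on this nitrogen would lower the number in this assay further or return it to the limit. They also leave open whether a methoxy group, a bromine atom or an amine on the ring of the benzyl group would keep a readable value.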